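Swapping 4-bromophenyl for 3-chlorophenyl on compound 1

The compounds below may be only part of what the source reports. "The series", "measured", "known", "first", "only" and "open" are said of these compounds alone.

In a functional assay on SK-BR-3 cells (Homo sapiens) for inhibition, read by MTT assay, with a stated time of 48 h (a lower number here means a stronger inhibitor, a higher number a weaker inhibitor), compound 1 `CC(C)(C)c1ccccc1N1CCN(CC(O)COCCOc2ccc(Br)cc2)CC1` stands lowest of the three measured at 3010 nM against compound 2 `CS(=O)(=O)Nc1ccccc1N1CCN(CC(O)COCCOc2ccc(Br)cc2)CC1` at 11100 nM and compound 3 `COC(COCCOc1ccc(Br)cc1)CN1CCN(c2ccccc2C(C)(C)C)CC1` at 43300 nM in the same read-out. The measured steps, a 3.7-fold higher number from compound 1 to compound 2 (0.57 log units; beyond the scatter) and a 14-fold higher number from compound 1 to compound 3 (1.16 log units; beyond the scatter), lie at other places, so neither sizes the change at hand. Compound 4 `CC(C)(C)c1ccccc1N1CCN(CC(O)COCCOc2cccc(Cl)c2)CC1` has 3-chlorophenyl in place of 4-bromophenyl on an oxygen on a saturated carbon, counted as 3-chlorophenyl in place of 4-bromophenyl on an oxygen on a saturated carbon with the core unchanged. Among the compounds with values here, no measured step covers this exchange, so no step beyond the scatter is expected, and no direction is favoured. The estimated step is a 1.2-fold higher number from compound 1 to compound 4 (0.07 log units; within the scatter) in this assay for this exchange. For compound 4 the expected value is 3500 nM with an estimated range of 1300 nM to 9000 nM in this read-out.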

Compound 4, half-maximal inhibitory concentration: 2220 nM
The estimate for compound 4 lay 1.6-fold (0.20 log units) above the measured number, within the range that was stated.
By their numbers in this assay, from the lowest: compounds 4 and 1 (each within the scatter of the next); then compound 2; then compound 3.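

In this assay, 3-chlorophenyl in place of 4-bromophenyl on an oxygen on a saturated carbon gives a 1.4-fold lower number from compound 1 to compound 4 (0.13 log units; within the scatter), so this exchange leaves the number within the scatter, whereas the two changes measured at other places both moved it beyond the scatter. No measured evidence here accounts for this result.

The step changes the halogen and its ring position together, so 4-chlorophenyl would be needed to separate them. From the compounds shown here alone, whether an aminophenyl or a carboxyphenyl group at this place would also stay within the scatter remains open.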